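Benzyl-linked purine analogues in the electroshock model

The compounds below may be only part of what the source reports. "The series", "measured", "known", "first", "only" and "open" are said of these compounds alone.

Three compounds sharing a fused bicyclic core have numbers in a functional assay on the whole organism for inhibition, with Rattus norvegicus as the target, in the maximal electroshock model, at a dose of 25 mg/kg by the intraperitoneal route; on this read-out lower numbers stand for less inhibition and higher numbers for more inhibition at the one dose given (going by the name of the read-out). Compound 1 `C[C@H](c1ccccc1)n1cnc2c(N(C)C)ncnc21` gives 33%. Compound 2 `CN(C)c1ncnc2c1ncn2CC1CCCCC1` gives 0%. Compound 3 `CN(c1ncnc2c1ncn2Cc1ccccc1)C1CCCC1` gives 17%. Compound 3 stands second highest of the three: its nearest neighbour is compound 1, whose number is higher by a margin beyond the scatter, and the furthest is compound 2, whose number is lower by a margin also beyond the scatter. No two of these compounds differ in only one place, so no single step can be separated out from the measured set.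

Compound 4 `CSc1ncnc2c1ncn2Cc1ccccc1` is not yet measured in this assay. It differs from compound 3 in one place: methylsulfanyl in place of cyclopentyl(methyl)amino on an aromatic carbon. Going by the values given here, nothing among the measured compounds isolates what the methylsulfanyl group contributes at this carbon, and the two compounds carrying a dimethylamino group there sit far apart, so the basis for an expectation is thin.

Compound 4 is expected to give 10% in this assay, within a range from 0% to 35%. The step expected a number 7 percentage points lower from compound 3 to compound 4 (within the scatter) is small, downward if anything, and not beyond the scatter.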

Compound 4, a percentage reported as inhibition, in the whole organism at one dose (the size of the read-out at that dose, not a potency): 30%
For compound 4 the middle estimate is 20 percentage points below the measured one; measured number inside the range.
By their numbers in this assay, from the lowest: compound 2; then compound 3; then compounds 4 and 1 (each within the scatter of the next).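

In this assay, going by these compounds alone, the replacement at this aromatic carbon gives a number 13 percentage points higher from compound 3 to compound 4 (beyond the scatter), the first step that can be read at a single place. In this pair, the five-membered non-aromatic ring of carbon only is not needed for the read-out to reach the value of compound 4, even though the substituent falls from 7 heavy atoms to 2 and its hydrogen-bond acceptor count stays the same. No supporting measurement bears on what lies behind this step.

The pair changes several things at once: sulfur enters, the ring leaves and the substituent shrinks, so the step cannot be assigned to any one of them, and a methoxy group or a plain amino group at this carbon, on the otherwise unchanged structure of compound 4, would help to separate them. The read-out also comes from a single dose, so the step describes the size of the response at that dose and leaves open how potency changes across the series.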